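The source may report more compounds than this note shows. Statements on the series, on what has been measured and on what is new or still open speak of the compounds shown alone.

Compound 1 `O=C(O)c1ccccc1-c1ccc(CCc2ncc(CCC3CCCCC3)[nH]2)cc1` is the starting point here. In an in vitro functional assay on cells for agonist activity at Bombesin receptor subtype-3 (Homo sapiens), read by luminescence and calcium flux (on this read-out higher numbers stand for an effect only at larger amounts of compound and lower numbers for an effect already at smaller amounts), compound 1 gives 642 nM, which places it second highest among the three numbers measured: compound 3 `CC(C)(C)Cc1cnc(CCc2ccc(-c3ccccc3C(=O)O)cc2)[nH]1` gives 106 nM, and compound 2 `N#Cc1ccccc1Cc1cnc(CCc2ccc(-c3ccccc3C(=O)O)cc2)[nH]1` gives 5480 nM. The change to compound 4 `COc1ccc(Cc2cnc(CCc3ccc(-c4ccccc4C(=O)O)cc3)[nH]2)cc1` is 4-methoxyphenyl in place of cyclohexylmethyl on a saturated chain carbon bound to an aromatic carbon. The step that bears most on this is the one in which a flat aromatic ring also replaced the cyclohexylmethyl, namely an 8.5-fold higher number from compound 1 to compound 2 (0.93 log units; beyond the scatter); the opposite move to a smaller, compact group gave a 6.1-fold lower number from compound 1 to compound 3 (0.78 log units; beyond the scatter), and between those two a 52-fold lower number from compound 2 to compound 3 (1.71 log units; beyond the scatter). For the measured compounds named here, the 4-methoxyphenyl of compound 4 is not the same aromatic ring as in compound 2, so that step is a guide rather than a rule, but an aromatic ring entering at this position is the only comparable change available. For compound 4 a higher number is therefore expected, though more modest than the step to compound 2, estimated as a 3.1-fold higher number from compound 1 to compound 4 (0.49 log units; beyond the scatter). The estimated value for compound 4 is 2000 nM, with a range from 600 nM to 7000 nM.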

Compound 4, half-maximal effective concentration: 5360 nM
For compound 4 the middle estimate is 2.7-fold (0.43 log units) below the measured one; low and high end bracket the measured number.
By their numbers in this assay, from the lowest: compound 3; then compound 1; then compounds 4 and 2 (each within the scatter of the next).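

With a 1.0-fold lower number from compound 2 to compound 4 (0.01 log units; within the scatter), 2-cyanophenyl and 4-methoxyphenyl cannot be told apart in this assay, so two aromatic rings that carry different groups at different ring positions give matching numbers. The new ring also stands clearly apart from the saturated groups, with an 8.3-fold higher number from compound 1 to compound 4 (0.92 log units; beyond the scatter) and a 51-fold higher number from compound 3 to compound 4 (1.70 log units; beyond the scatter). Among these four compounds, then, both aromatic rings give higher numbers than cyclohexylmethyl and tert-butyl, and no compound goes against that pattern.

From the compounds shown here alone, whether the aromatic ring itself or the group it carries sets this level stays open, as does how a plain phenyl or a pyridyl group would behave at this position. No supporting evidence accompanies these results, so the reason for this pattern remains unknown.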